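The compounds below may be only part of what the source reports. "The series", "measured", "known", "first", "only" and "open" are said of these compounds alone.

Measured compounds and their values:

Compound 1, `COC(=O)[C@@]1(C)CCC=C2[C@@H]1CC[C@@H](C)[C@]2(C)Cc1c(C)[nH]c2ccc(Br)cc12`, gives in a functional assay on A549 cells (Homo sapiens) for inhibition, read by sulforhodamine B assay, with a stated time of 48 h (on this read-out higher numbers stand for weaker inhibition of growth and lower numbers for stronger inhibition of growth), a value of 15000 nM.
Compound 2, `COC(=O)[C@@]1(C)CC[C@@H]2C3=C1CC[C@@H](C)[C@]3(C)C[C@@H]1c3cc(Br)ccc3N[C@H]21`, gives in this assay a value of 40000 nM.
Compound 3, `COC(=O)[C@@]1(C)CC[C@@H]2C3=C1CC[C@@H](C)[C@]3(C)C[C@@H]1c3cc(Cl)ccc3N[C@H]21`, gives in this assay a value of 35000 nM.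

Among these three numbers compound 3 stands second highest. Its nearest neighbour is compound 2, whose number is within the scatter of it, so no order between the two can be read. Compound 1 lies furthest away, with a lower number that is beyond the scatter.

Compound 4, `COC(=O)[C@@]1(C)CC[C@@H]2C3=C1CC[C@@H](C)[C@]3(C)C[C@@H]1c3cc(OC)ccc3N[C@H]21`, differs from compound 3 in one place: methoxy in place of chloro on an aromatic carbon. Going by the values given here, only one measured step touches the same aromatic carbon, the exchange of one halogen for another, and it was small: a 1.1-fold lower number from compound 2 to compound 3 (0.06 log units; within the scatter), within the scatter. Among the compounds with values here, no measured pair exchanges a halogen for a methoxy group, so the data give no direct guide to the size or direction of this change. On this basis the expectation for compound 4 is a number close to that of compound 3, with no step beyond the scatter: the estimated step is a 1.2-fold lower number from compound 3 to compound 4 (0.07 log units; within the scatter). Compound 4 is therefore estimated in this assay at 30000 nM, with a range from 12000 nM to 75000 nM.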

Compound 4, concentration for 50% growth inhibition: 22000 nM
Estimate against measurement, compound 4: 1.4-fold (0.13 log units) above; measured number inside the range.
By their numbers in this assay, from the lowest: compounds 1, 4, 3 and 2 (each within the scatter of the next, the first and the last beyond it).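

At the aromatic carbon that lies meta to a fused ring and para to a fused ring, this assay gives a 1.6-fold lower number from compound 3 to compound 4 (0.20 log units; within the scatter) for methoxy in place of chloro, and a 1.8-fold lower number from compound 2 to compound 4 (0.26 log units; within the scatter) for methoxy in place of bromo. The earlier compounds shown here showed only one halogen exchanged for another at this carbon, whereas these steps show that a non-halogen group of two heavy atoms, carrying one hydrogen-bond acceptor, also leaves the number within the scatter of both halogen compounds, so no order among bromo, chloro and methoxy can be read here. Nothing measured on these compounds offers an explanation for this result.

The compounds shown leave open whether any group at this carbon can move the number beyond the scatter, for instance an amine, a carboxylic acid, a longer chain such as ethoxy, or plain hydrogen. They also leave open what methoxy in place of bromo would give on the core of compound 1, which has the lowest number of the set at 15000 nM.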